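A Larger Group Replaces the Propyl Chain

The source may hold more compounds than are shown below. What is called first, only, known or untested is meant among the compounds shown, and "the series" means these compounds.

Compound 1 `CCCc1n[nH]c2c(=O)n(NC(=O)c3ccccc3)c(-c3cccc([N+](=O)[O-])c3)nc12` was tested in a functional assay on SK-OV-3 cells (Homo sapiens) for cytotoxicity, read by sulforhodamine B assay, with a stated time of 2 days, tested at 100 uM (a higher number here means more inhibition at the concentration tested (going by the name of the read-out), a lower number less inhibition), and gives 28.8%. Among the two numbers measured so far it stands highest; its nearest neighbour, compound 2 `CCCc1n[nH]c2c(=O)n(NC(=O)c3ccccc3)c(-c3cccc(OC)c3)nc12`, gives 9.96% in this assay. Among the compounds with values here, that pair forms the only measured step: a number 18.8 percentage points lower from compound 1 to compound 2 (beyond the scatter). Compound 3 `O=C(Nn1c(-c2cccc([N+](=O)[O-])c2)nc2c(-c3ccc(F)cc3)n[nH]c2c1=O)c1ccccc1` has not yet been measured. It differs from compound 1 in one place: 4-fluorophenyl in place of propyl on an aromatic carbon. Within the data shown here, the one measured step swaps groups at a different aromatic carbon, not at the carbon that carries the propyl chain, so no measured step bears on this change, and its size and direction cannot be read from the pair at hand. Compound 3 is therefore expected to give 30%, within a wide range from 5% to 60%. The expected step is a number 1.2 percentage points higher from compound 1 to compound 3 (within the scatter), with no confident direction.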

Compound 3, a percentage reported as inhibition, at one concentration (the size of the read-out at that concentration, not a potency): 77.7%
Compound 3: middle estimate off by 47.7 percentage points, on the low side, outside the stated range (above it).
By their numbers in this assay, from the lowest: compound 2; then compound 1; then compound 3.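

In this assay, the carbon that carries the propyl chain turns out to be a sensitive position: 4-fluorophenyl in place of propyl gives a number 48.9 percentage points higher from compound 1 to compound 3 (beyond the scatter), a large step. This change at the propyl position is bigger than the modest step for methoxy in place of nitro, which gives a number 18.8 percentage points lower from compound 1 to compound 2 (beyond the scatter), so the group on this carbon can shift the read-out strongly. No measurement shown here accounts for the rise.

On these data alone, the change adds a ring and a fluorine together, so it remains open which of them matters; plain phenyl, without the fluorine, or a longer chain such as pentyl, without the ring, would separate these. Also open, as far as these compounds go, is whether 4-fluorophenyl gives a similar rise when methoxy stands in place of nitro.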